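A chloro substituent placed on two related cores

The source may report more compounds than this note shows. Statements on the series, on what has been measured and on what is new or still open speak of the compounds shown alone.

Compound 1 `O=S(=O)(/C=C/c1ccccn1)c1cccc(F)c1` was tested in an assay on U2OS cells for activation of nuclear factor erythroid 2-related factor 2 (Homo sapiens), read by beta-arrestin recruitment, with a stated time of 6 h (on this read-out lower numbers stand for an effect already at smaller amounts and higher numbers for an effect only at larger amounts of compound), where compound 1 gives 1680 nM. Compound 2 `O=S(=O)(/C=C/c1ccc(Cl)cn1)c1cccc(F)c1` carries chloro in place of hydrogen on an aromatic carbon relative to compound 1, and in this assay compound 2 gives 2500 nM, a step of a 1.5-fold higher number from compound 1 to compound 2 (0.17 log units; within the scatter). Compound 3 `O=S(=O)(/C=C/c1ccccn1)c1ccc(Cl)cc1` rests on a different core; the difference between the two cores is not broken down here. In this assay compound 3 gives 1730 nM, a value that shows nothing apart from those of compound 1 and compound 2.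

Compound 4 `O=S(=O)(/C=C/c1cccc(Cl)n1)c1ccc(Cl)cc1` differs from compound 3 by chloro in place of hydrogen on an aromatic carbon. This is the same kind of change as that from compound 1 to compound 2, but not the same: in compound 2 the chloro sits two atoms from the ring nitrogen and para to a large group, whereas in compound 4 it sits next to the ring nitrogen and meta to a large group. Within the data shown here, since the one measured step of this kind, a 1.5-fold higher number from compound 1 to compound 2 (0.17 log units; within the scatter), stayed within the scatter, the step from compound 3 to compound 4 is expected to be a 1.4-fold higher number from compound 3 to compound 4 (0.16 log units; within the scatter). In this assay compound 4 is estimated to give 2500 nM, between 1200 nM and 5500 nM.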

Compound 4, half-maximal effective concentration: 1460 nM
Estimate against measurement, compound 4: 1.7-fold (0.23 log units) above, within the range that was stated.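

In this assay, chloro in place of hydrogen on an aromatic carbon of the core of compound 3 gives a 1.2-fold lower number from compound 3 to compound 4 (0.07 log units; within the scatter). Set beside the earlier step on the other core, the two do not differ by more than repeated measurements would: the same change on two cores in this assay, a 1.5-fold higher number (0.17 log units; within the scatter) from compound 1 to compound 2 and a 1.2-fold lower number (0.07 log units; within the scatter) from compound 3 to compound 4, 1.8-fold (0.25 log units) apart, within the scatter of two such steps. So on these two cores the change stays within the scatter each time, but this does not show that it carries over as a rule, since there are only two steps, the chloro stands at a different place in compound 2 and in compound 4, and neither step gives a direction that could be carried over.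

The compounds shown leave open whether another group on the same ring, such as an amine, a carboxylic acid or a longer chain, would give a step beyond the scatter. They also leave open whether chloro at one of these two places would give the same result at the other place on the same core.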